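The compounds below may be only part of what the source reports. "The series", "measured", "known", "first", "only" and "open" are said of these compounds alone.

Measured compounds in this set:
- compound 1, `COc1cc(C(=N)NC(C)C)cc2cc(-c3ccc(C(=N)NC(C)C)cc3)oc12`: > 190000 nM
- compound 2, `CC(C)NC(=N)c1ccc(-c2cc3cc(C(=N)NC(C)C)cc(O)c3o2)cc1`: > 185000 nM
- compound 3, `COc1cc(C(=N)N)ccc1-c1cc2cc(C(=N)N)ccc2o1`: 157000 nM

In an ADME assay on L6 cells (Rattus norvegicus) for cytotoxicity (a higher number here means a weaker inhibitor, a lower number a stronger inhibitor), compound 1 gives only a limit, > 190000 nM. Compound 2 also gives only a limit in this assay, > 185000 nM. Among the compounds with values here, compound 3 is the one compound of the three with a number in this assay, 157000 nM.

The change from compound 1 to compound 2 is hydrogen in place of methyl on an oxygen on an aromatic ring. The step it made, a step that the two limits leave unreadable from compound 1 to compound 2, cannot be read because compound 1 sits at the limit of > 190000 nM in this assay, at which 1 of the 3 values shown sits, and compound 2 sits at the limit of > 185000 nM in this assay, at which 1 of the 3 values shown sits.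

Compound 4, `N=C(N)c1ccc(-c2cc3cc(C(=N)N)ccc3o2)c(O)c1`, has not yet been measured in this assay. It differs from compound 3 by hydrogen in place of methyl on an oxygen on an aromatic ring, the same kind of change as from compound 1 to compound 2, at a place described in the same words. The difference between the two cores, that of compound 1 and that of compound 3, is not broken down here.

Within the data shown here, since the only measured instance of this change is unreadable, the expectation for compound 4 rests on the value of compound 3 alone, 157000 nM, and on the absence of any readable sign of the change. The step from compound 3 to compound 4 in this assay is therefore expected to be small, a 1.1-fold higher number from compound 3 to compound 4 (0.03 log units; within the scatter). For compound 4 the estimate in this assay is 170000 nM, expected to fall between 80000 nM and 360000 nM, with a real chance that only a limit is reported.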

Compound 4, half-maximal inhibitory concentration: 33300 nM
Estimate against measurement, compound 4: 5.1-fold (0.71 log units) above; measured number below the stated range.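

Methoxy to hydroxy gives a 4.7-fold lower number from compound 3 to compound 4 (0.67 log units; beyond the scatter) in this assay, so on this core the change has a readable size, with the lower number marking a stronger inhibitor. The same change on the core of compound 1 cannot be read, since the values of compound 1 and compound 2 are both limits and not numbers. As far as these compounds go, the series therefore holds a single readable instance of this change, which shows neither that the step carries over from one core to the other nor that it fails to, and the size and direction on the core of compound 1 remain unknown.

The compounds shown leave open how a longer chain on the same oxygen, such as ethoxy, or an amine in place of the hydroxy would read in this assay on the core of compound 3. Also open, from the compounds shown here alone, is whether the lower number belongs to hydroxy itself or to the loss of methoxy, a question that a compound with plain hydrogen on the aromatic ring in place of the whole group could address.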